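The compounds below may be only part of what the source reports. "The series", "measured", "known", "first", "only" and "open" are said of these compounds alone.

The study compares two cores carrying the same trifluoromethyl-bearing five-membered ring. Compound 1 `C[C@@H]1CN(c2cc(C(F)(F)F)nn2-c2ccc(S(C)(=O)=O)cn2)[C@H](C)CO1` and compound 2 `C[C@@H]1CN(c2c(C#N)c(C(F)(F)F)nn2-c2ccc(S(C)(=O)=O)cn2)[C@H](C)CO1` differ by cyano in place of hydrogen on an aromatic carbon. Compound 3 `CC(C)(C)CNc1cc(C(F)(F)F)nn1-c1ccc(S(C)(=O)=O)cn1` and compound 4 `CC(C)(C)CNc1c(C#N)c(C(F)(F)F)nn1-c1ccc(S(C)(=O)=O)cn1` differ in the same kind of change, (cyano in place of hydrogen on an aromatic carbon), although the surroundings of the place are not identical: in compound 1 the site lies next to the ring atom that bears a group of 8 heavy atoms, whereas in compound 3 it lies next to the ring atom that bears a neopentylamino group (6 heavy atoms). The two cores themselves differ by a group of 6 heavy atoms (5 carbon, 1 nitrogen; no ring) in place of a group of 8 heavy atoms (6 carbon, 1 nitrogen, 1 oxygen; one six-membered non-aromatic ring with 2 hetero atoms), on an aromatic carbon.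

In a physicochemical assay for solubility (on this read-out lower numbers stand for lower solubility and higher numbers for higher solubility), compound 1 gives 100 ug/mL. For compound 2 the result in this assay is only a limit, > 200 ug/mL. The step of an at least 2.0-fold higher number from compound 1 to compound 2 (0.30 log units; that floor lies within the scatter) therefore rests on the limit of > 200 ug/mL in this assay, at which 1 of the 3 values shown sits, and cannot be sized more closely. For compound 3 the read-out in this assay is "not determined" (no result reported), so no starting point is known for the second pair.

Compound 4 has not yet been measured in this assay. With nothing known for compound 3, the expectation for compound 4 rests on the same kind of change in compound 1, where an at least 2.0-fold higher number from compound 1 to compound 2 (0.30 log units; that floor lies within the scatter) was observed, together with the limit at which compound 2 sits. On that basis compound 4 is expected to give about 60 ug/mL in this assay, estimated to fall between 15 ug/mL and 200 ug/mL.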

Compound 4, solubility: < 25 ug/mL
Compound 4: no number, only a limit; the forecaster's own chance of this, stated with the estimate: 20%; middle value at least 2.4-fold (0.38 log units) from the limit.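

Among the two compounds that carry cyano, the neopentylamino group in place of the group of 8 heavy atoms goes with an at least 8.0-fold lower number from compound 2 to compound 4 (0.90 log units; beyond the scatter) in this assay, so the outcome on the core of compound 1 does not simply reappear on the core of compound 3. Among the compounds shown here, both ends of that step are limits, so only its floor is known: the limit of < 25 ug/mL in this assay, at which 1 of the 4 values shown sits. Compound 3 has no reported result, so the step to compound 4 cannot be read, and the one readable cyano step, an at least 2.0-fold higher number from compound 1 to compound 2 (0.30 log units; that floor lies within the scatter), has no partner; whether cyano in place of hydrogen does the same on both cores therefore stays unknown.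

The compounds shown leave open how other groups on that aromatic carbon, such as a cyclopropylamino group, a piperidine or a chain bearing a carboxylic acid, would read alongside the cyano group, and so whether the gap between compound 2 and compound 4 belongs to the neopentylamino group alone. Also open, on these data alone, is how far apart compound 2 and compound 4 truly lie in this assay.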